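A few compounds are considered here, and "the series" means these few. Any claim that something is new, unique, unknown or untested is made for them only; others in the source may bear on it.

The three measured compounds share one core and differ only in the group carried on the sulfur. Compound 1 `CCC(O)CSc1nc(NCc2ccc(-c3ccccn3)cc2)c2[nH]nc(C(C)C)c2n1` gives 273 nM in a functional assay on HT cells (Homo sapiens) for antiproliferative activity, read by fluorescence, with a stated time of 72 h (a lower number here means a stronger inhibitor of growth, a higher number a weaker inhibitor of growth), compound 2 `CC(C)c1n[nH]c2c(NCc3ccc(-c4ccccn4)cc3)nc(SCCCN(C)C)nc12` gives 105 nM, and compound 3 `CC(C)c1n[nH]c2c(NCc3ccc(-c4ccccn4)cc3)nc(SC(CO)C(C)C)nc12` gives 980 nM, the highest of the three numbers, with a 3.6-fold higher number from compound 1 to compound 3 (0.56 log units; beyond the scatter) and a 9.3-fold higher number from compound 2 to compound 3 (0.97 log units; beyond the scatter) both beyond the scatter.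

Compound 4 `CC(=O)NCCSc1nc(NCc2ccc(-c3ccccn3)cc2)c2[nH]nc(C(C)C)c2n1` is the next step from compound 3. The change is 2-acetamidoethyl in place of 1-(hydroxymethyl)-2-methylpropyl on a sulfur: the branched group on the sulfur gives way to an unbranched chain ending in an amide. The two steps that bear on this are those from the other sulfur groups to compound 3, which read a 3.6-fold higher number from compound 1 to compound 3 (0.56 log units; beyond the scatter) and a 9.3-fold higher number from compound 2 to compound 3 (0.97 log units; beyond the scatter); in both cases the unbranched chain on the sulfur went with the lower number. On that basis a lower number than compound 3 is expected for compound 4 in this assay, with an estimated step of a 3.3-fold lower number from compound 3 to compound 4 (0.51 log units; beyond the scatter). Compound 4 is estimated at 300 nM, with a range from 120 nM to 800 nM.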

Compound 4, concentration for 50% growth inhibition: 71 nM
Estimate against measurement, compound 4: 4.2-fold (0.63 log units) above, outside the stated range (below it).
By their numbers in this assay, from the lowest: compounds 4 and 2 (each within the scatter of the next); then compound 1; then compound 3.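

In this assay, the change to 2-acetamidoethyl on the sulfur gives the largest step yet seen at this position, a 14-fold lower number from compound 3 to compound 4 (1.14 log units; beyond the scatter), and the same group also improves on the 2-hydroxybutyl group, with a 3.8-fold lower number from compound 1 to compound 4 (0.58 log units; beyond the scatter). Against the 3-(dimethylamino)propyl group the result is a 1.5-fold lower number from compound 2 to compound 4 (0.17 log units; within the scatter), so a chain ending in an amide and a chain ending in a dimethylamino group cannot be told apart here, and the dimethylamino amine is not required for a number at this level.

The compounds shown do not separate the loss of branching from the gain of the amide in the step from the branched group, and they leave open how a longer chain ending in the amide, or a chain ending in a carboxylic acid, would read. Nothing available here explains any of these differences.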